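Swapping the Side Ring on a Shared Core

The source may report more compounds than this note shows. Statements on the series, on what has been measured and on what is new or still open speak of the compounds shown alone.

Three compounds have so far been measured in a functional assay, with a stated time of 10 min; on this read-out higher numbers stand for weaker inhibition and lower numbers for stronger inhibition:

Compound 1, `CCOC(=O)c1cnn(-c2nc(-c3ccccc3F)c(C#N)c(=O)n2C)c1N`: 86 ug/mL
Compound 2, `CCOC(=O)c1cnn(-c2nc(-c3ccc(N(C)C)cc3)c(C#N)c(=O)n2C)c1N`: 119 ug/mL
Compound 3, `CCOC(=O)c1cnn(-c2nc(-c3cccs3)c(C#N)c(=O)n2C)c1N`: 109 ug/mL

Compound 3 sits in the middle of this small spread. Its number is close to that of compound 2, with a step of a 1.1-fold lower number from compound 2 to compound 3 (0.04 log units; within the scatter), and also close to that of compound 1, with a step of a 1.3-fold higher number from compound 1 to compound 3 (0.10 log units; within the scatter); neither step rises above the usual scatter of the measurement, so the three compounds cannot be told apart on these numbers.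

Compound 4, `CCOC(=O)c1cnn(-c2nc(-c3ccccc3Cl)c(C#N)c(=O)n2C)c1N`, is not yet measured. It differs from compound 3 in one place: 2-chlorophenyl in place of thiophen-2-yl on an aromatic carbon. The steps already seen bear on this directly, since each of them also only exchanges the ring at this same carbon. The move from compound 1 to compound 2 gave a 1.4-fold higher number from compound 1 to compound 2 (0.14 log units; within the scatter), and the move from compound 1 to compound 3 gave a 1.3-fold higher number from compound 1 to compound 3 (0.10 log units; within the scatter). Every exchange of this ring tried so far has stayed within the scatter.

The expectation for compound 4 in this assay is therefore a step of a 1.1-fold lower number from compound 3 to compound 4 (0.06 log units; within the scatter), that is, no change beyond the scatter. Compound 4 is estimated at 95 ug/mL, with a likely range from 50 ug/mL to 180 ug/mL.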

Compound 4, half-maximal inhibitory concentration: 98 ug/mL
For compound 4 the middle estimate is 1.0-fold (0.01 log units) below the measured one, within the range that was stated.
By their numbers in this assay, from the lowest: compounds 1, 4, 3 and 2 (each within the scatter of the next).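

The new compound allows the closest comparison yet at this carbon, where only the halogen on the phenyl ring is exchanged: in this assay, chloro in place of fluoro gives a 1.1-fold higher number from compound 1 to compound 4 (0.06 log units; within the scatter) and stays within the scatter. Larger exchanges of the whole ring also stay within the scatter: 2-chlorophenyl in place of thiophen-2-yl gives a 1.1-fold lower number from compound 3 to compound 4 (0.05 log units; within the scatter) and, in place of 4-(dimethylamino)phenyl, gives a 1.2-fold lower number from compound 2 to compound 4 (0.08 log units; within the scatter) as well. So 2-fluorophenyl, 2-chlorophenyl, 4-(dimethylamino)phenyl and thiophen-2-yl cannot be told apart at this carbon, and nothing on hand explains why these four rings read alike.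

As far as these compounds go, all four compounds carry an aromatic ring at this carbon, so it remains open whether a saturated ring such as piperidine, a simple amine, a carboxylic acid or a longer alkyl chain placed there would also leave the number within the scatter. From the compounds shown here alone, the ester, the cyano group and the methyl group are the same in all four compounds, so what each of them contributes to the read-out also remains open.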